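A smaller group on the five-membered ring of compound 3

The source may hold more compounds than are shown below. What is called first, only, known or untested is meant among the compounds shown, and "the series" means these compounds.

Measured so far, in a functional assay on MV4-11 cells (Homo sapiens) for inhibition, read by resazurin assay, with a stated time of 72 h; a lower number here means a stronger inhibitor of growth, a higher number a weaker inhibitor of growth:
compound 1 `COc1ccc(Nc2nccc(-c3cn(C4CCCC4)c4ccccc34)n2)c(OC)c1` gives 1740 nM
compound 2 `COc1ccc(Nc2nccc(-c3cn(C)c4ccccc34)n2)c(OC)c1` gives 3410 nM
compound 3 `COc1ccc(Nc2nccc(-c3sc(SCc4cccnc4)nc3C)n2)c(OC)c1` gives 270 nM

Compound 3 stands lowest of the three numbers in this assay ; its nearest neighbour is compound 1, and the gap to compound 1 and the larger gap to compound 2 both lie beyond the scatter. Compound 4 `COc1ccc(Nc2nccc(-c3sc(OC)nc3C)n2)c(OC)c1` is not yet measured. It differs from compound 3 in one place: methoxy in place of ((pyridin-3-yl)methyl)sulfanyl on an aromatic carbon.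

Within the data shown here, only one measured step exists, a 2.0-fold higher number from compound 1 to compound 2 (0.29 log units; within the scatter). That step also trims a larger group to a methyl, but on an aromatic nitrogen of a different part of the shared core, and it stays within the scatter. Among the measured compounds shown here, no measured pair touches the position on the five-membered aromatic ring with 1 nitrogen and 1 sulfur, and none removes a group as large as ((pyridin-3-yl)methyl)sulfanyl. The pair compound 1 and compound 2 suggests that trimming a substituent need not cost much, yet the loss here is far greater and removes one of two hydrogen-bond acceptors counted in the leaving group, so a higher number than for compound 3 is expected, with wide uncertainty.

Compound 4 is therefore expected to give 1500 nM, with a range from 400 nM to 6000 nM. The expected step is a 5.6-fold higher number from compound 3 to compound 4 (0.74 log units; beyond the scatter).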

Compound 4, concentration for 50% growth inhibition: 1400 nM
Compound 4: the middle estimate sits 1.1-fold (0.03 log units) above what was measured; the range from low to high includes it.
By their numbers in this assay, from the lowest: compound 3; then compounds 4, 1 and 2 (each within the scatter of the next, the first and the last beyond it).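

In this assay, among these compounds, the swap on the aromatic carbon next to the ring nitrogen and next to the ring sulfur gives a 5.2-fold higher number from compound 3 to compound 4 (0.71 log units; beyond the scatter), the first measured step at this place on the five-membered aromatic ring with 1 nitrogen and 1 sulfur. Among the compounds shown here, the only earlier step, a 2.0-fold higher number from compound 1 to compound 2 (0.29 log units; within the scatter), sits on an aromatic nitrogen and stays within the scatter, whereas this one lies beyond it, so here, replacing ((pyridin-3-yl)methyl)sulfanyl, with 8 heavy atoms and a six-membered aromatic ring, by methoxy, with 2 heavy atoms and no ring, does weaken growth inhibition. Nothing measured here accounts for the size of this step.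

The change removes the sulfur, the methylene link and the six-membered aromatic ring together, so the compounds shown do not separate what each of these parts contributes. Going by these compounds, it remains open how a benzylsulfanyl group, which keeps a six-membered aromatic ring but has no ring nitrogen, a plain methylsulfanyl group or an amine such as dimethylamino on this carbon would stand in this assay.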